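A fluoro added to the phenyl of compound 2

This account rests on a few compounds, and the source may have more. Where it says the series, first, only, none or still open, it means among the compounds named here.

Measured in a functional assay on PC-9 cells (Homo sapiens) for inhibition, read by MTT assay, with a stated time of 72 h; a higher number here means a weaker inhibitor, a lower number a stronger inhibitor:
Compound 1 `Cc1cc(Nc2cc(-c3ccccc3)[nH]n2)n2nc(SCC3CCCCC3)nc2n1`: > 50000 nM
Compound 2 `Cc1cc(Nc2cc(-c3ccccc3)[nH]n2)n2nc(SCc3ccc(Br)cc3)nc2n1`: 4760 nM
Compound 3 `Cc1cc(Nc2cc(-c3ccccc3)[nH]n2)n2nc(SCCCc3ccccc3)nc2n1`: 5030 nM

Compound 1 reports only a limit of the assay, > 50000 nM. Compound 2 holds one of the two real numbers, and the gap to the other is small: a 1.1-fold higher number from compound 2 to compound 3 (0.02 log units; within the scatter). Measured against the limit, the change is an at least 10-fold lower number from compound 1 to compound 2 (1.02 log units; beyond the scatter).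

Compound 4 `Cc1cc(Nc2cc(-c3ccc(F)cc3)[nH]n2)n2nc(SCc3ccc(Br)cc3)nc2n1` differs from compound 2 in one place, with fluoro in place of hydrogen on an aromatic carbon, so that phenyl becomes 4-fluorophenyl (fluoro in place of hydrogen on an aromatic carbon).

Among the compounds with values here, none of the measured steps touches that phenyl. All three change the group on the sulfur, including an at least 9.9-fold lower number from compound 1 to compound 3 (0.99 log units; beyond the scatter), so they show how far this assay can move but say nothing direct about fluoro. No step beyond the scatter is expected here. The natural anchor is compound 2 at 4760 nM. The estimated change is a 1.2-fold lower number from compound 2 to compound 4 (0.08 log units; within the scatter). Compound 4 is estimated at 4000 nM, with an expected range of 1800 nM to 9500 nM.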

Compound 4, half-maximal inhibitory concentration: 6210 nM
For compound 4 the middle estimate is 1.6-fold (0.19 log units) below the measured one; the range from low to high includes it.
By their numbers in this assay, from the lowest: compounds 2, 3 and 4 (each within the scatter of the next). At a limit, above all of these: compound 1.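

The earlier compounds differ only in the group on the sulfur, so compound 4 is the first one shown with a change on the phenyl of the shared core. In this assay, fluoro in place of hydrogen on this aromatic carbon, para to a large group, gives a 1.3-fold higher number from compound 2 to compound 4 (0.12 log units; within the scatter), so the two compounds cannot be told apart and this position accepts a fluoro without a readable change in this pair. Nothing measured here offers a reason for that result.

Still open, as far as these compounds go, is whether a methoxy, a trifluoromethyl or an amine at the same place would move the number beyond the scatter. This single pair also leaves open whether fluoro would give the same result with the phenethyl of compound 3 on the sulfur chain.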